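Cytotoxicity notes: hydroxyalkyl amine in place of piperidine

The source may report more compounds than this note shows. Statements on the series, on what has been measured and on what is new or still open speak of the compounds shown alone.

Three compounds of the series have been run in an ADME assay on Huh-7 cells (Homo sapiens) for cytotoxicity; a higher number here means that more compound is tolerated, a lower number that less compound is tolerated. Compound 1 `Cc1ccccc1-c1nn(-c2ccc(F)cc2F)cc1CNCCN1CCCCC1` returns only the assay limit, > 20000 nM, not a number. Compound 3 `COc1ccc(-n2cc(CNCCN3CCN(C)CC3)c(-c3ccccc3C)n2)cc1` likewise sits at the limit, > 20000 nM. Among the compounds with values here, compound 2 `CN1CCN(CCNCc2cn(-c3ccc([N+](=O)[O-])cc3)nc2-c2ccc(OC(F)(F)F)cc2)CC1` is the one member with a measured number in this assay, giving 4400 nM. Within the data shown here, compound 1 therefore stands at the limit of > 20000 nM in this assay, at which 2 of the 3 values shown sit, and no pairwise step between measured compounds differs in a single place, so no measured step size is available.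

Compound 4 `Cc1ccccc1-c1nn(-c2ccc(F)cc2F)cc1CNCCCCO` is not yet measured. It differs from compound 1 by 2-hydroxyethyl in place of piperidin-1-yl on a saturated chain carbon, two bonds along the chain from an amine nitrogen, in words: 2-hydroxyethyl in place of piperidin-1-yl on a saturated chain carbon, two bonds along the chain from an amine nitrogen. With compound 1 at the limit and compound 3 also at the limit, the expectation for compound 4 in this assay is no step beyond the scatter from compound 1, with the estimated step that the limit leaves unreadable from compound 1 to compound 4. Compound 4 is accordingly estimated at 25000 nM, within 10000 nM to 60000 nM, most likely reported again as a limit.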

Compound 4, half-maximal cytotoxic concentration: > 20000 nM
Compound 4: a limit, no number; the forecaster's own chance of this, stated with the estimate: 75%; the middle value lies beyond the limit too.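

Compound 1 and compound 4 both return only a limit in this assay so the step between them cannot be read: the limit of > 20000 nM in this assay, at which 3 of the 4 values shown sit. The compounds shown leave open whether 2-hydroxyethyl in place of piperidin-1-yl changes the tolerated concentration in either direction.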